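The compounds below may be only part of what the source reports. "The series", "measured", "known", "first", "only" and "open" are said of these compounds alone.

Working notes on the series

Three compounds have numbers in an assay on a protein complex for inhibition of CDK8/Cyclin C (Homo sapiens), with a stated time of 1 h (on this read-out lower numbers stand for stronger inhibition and higher numbers for weaker inhibition), so far. Compound 1 `CCOC(=O)/C=C/c1ccncc1-c1ccc2c(cnn2C)c1` gives 102 nM in this assay. Compound 3 `CCOC(=O)/C=C/c1ccncc1-c1ccc2[nH]ccc2c1` gives 107 nM in this assay, and the two values sit within the scatter of each other. The difference between the core of compound 1 and the core of compound 3 is not broken down here. Compound 2 `O=C(/C=C/c1ccncc1-c1ccc2[nH]ccc2c1)N1CCOCC1` gives 190 nM in this assay.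

Compound 2 is reached from compound 3 by one change, (morpholin-4-yl in place of ethoxy on a carbonyl carbon), and the step it made reads a 1.8-fold higher number from compound 3 to compound 2 (0.25 log units; within the scatter).

Compound 4 `Cn1ncc2cc(-c3cnccc3/C=C/C(=O)N3CCOCC3)ccc21` has not yet been measured in this assay. Going by the values given here, it is reached from compound 1 by morpholin-4-yl in place of ethoxy on a carbonyl carbon, which is the same change as the one from compound 3 to compound 2, made on the other core; the place, a carbonyl carbon whose other neighbour is a double-bonded chain carbon, is the same in both pairs. The change occurs twice among the compounds shown, once measured and once not.

The expectation for compound 4 rests on one measured instance of this change, from compound 3 to compound 2, and on the shared starting value of compound 1 at 102 nM. Among the compounds with values here, compound 4 is expected to show a step of about a 1.8-fold higher number from compound 1 to compound 4 (0.25 log units; within the scatter) from compound 1, because a 1.8-fold higher number from compound 3 to compound 2 (0.25 log units; within the scatter) is the only step of this kind known here. The estimate for compound 4 in this assay is 180 nM, with a range from 90 nM to 360 nM.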

Compound 4, half-maximal inhibitory concentration: 356 nM
The estimate for compound 4 lay 2.0-fold (0.30 log units) below the measured number; the measured number falls inside the stated range.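

In this assay, morpholin-4-yl in place of ethoxy on the carbonyl carbon gives a 3.5-fold higher number from compound 1 to compound 4 (0.54 log units; beyond the scatter), and set beside the earlier instance of the change the comparison reads: the same change on two cores in this assay, a 1.8-fold higher number (0.25 log units; within the scatter) from compound 3 to compound 2 and a 3.5-fold higher number (0.54 log units; beyond the scatter) from compound 1 to compound 4, 2.0-fold (0.29 log units) apart, within the scatter of two such steps. The change therefore moves the number in the same direction on both cores, and the two steps cannot be told apart in size, so the data give no sign that the core of compound 1 and the core of compound 3 respond differently. Going by these compounds alone, this does not show that the step has one fixed size or that it would carry to a third core, as it rests on only two pairs, and only the step on the core of compound 1 lies beyond the scatter.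

The compounds shown carry only ethoxy and morpholin-4-yl on this carbonyl carbon, which leaves open how hydroxy, giving the carboxylic acid, or an open-chain amine such as dimethylamino would read on either core. They also leave open whether the step belongs to the ring of morpholin-4-yl or to its ring oxygen, a question that piperidin-1-yl in the same place could address.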